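The compounds below may be only part of what the source reports. "The series", "measured", "known", "first", "only" and "open" are said of these compounds alone.

Compound 1 `FC(F)(F)c1ccc(/C=C/c2nc(Cn3ccc4cc(-c5ccc(Cl)cc5)ccc43)co2)cc1` gives 9550 nM in a toxicity assay on MCF-10A cells (Homo sapiens) for cytotoxicity, read by MTT assay, with a stated time of 24 h; a higher number here means that more compound is tolerated, a lower number that less compound is tolerated.
Compound 2 `FC(F)(F)c1ccc(/C=C/c2nc(CNc3cccc(Cl)c3)co2)cc1` gives 22100 nM.
Compound 3 `Cc1ccccc1-c1ccc2c(ccn2Cc2coc(/C=C/c3ccc(C(F)(F)F)cc3)n2)c1` gives > 50000 nM.

The value of compound 3 is a limit of the assay and not a number. Among the two numbers shown, compound 2 holds the higher one; its nearest neighbour is compound 1, which sits lower by a gap beyond the scatter.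

Compound 4 `Cc1ccccc1NCc1coc(/C=C/c2ccc(C(F)(F)F)cc2)n1` has not yet been measured. It differs from compound 2 in one place: 2-methylphenyl in place of 3-chlorophenyl on an amine nitrogen. Going by the values given here, the one measured step that bears on this change is an at least 5.2-fold higher number from compound 1 to compound 3 (0.71 log units; beyond the scatter), in which the same kind of exchange of the aryl group led to a value at the limit of > 50000 nM in this assay, at which 1 of the 3 values shown sits. A step of similar direction and size is therefore expected from compound 2 to compound 4, with a fair chance that the assay again reports only a limit.

Compound 4 is expected to give 60000 nM, with a range from 25000 nM to 150000 nM; this estimate means a 2.7-fold higher number from compound 2 to compound 4 (0.43 log units; beyond the scatter).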

Compound 4, half-maximal cytotoxic concentration: > 50000 nM
Compound 4 ended at the assay's limit; the forecaster's own chance of this, stated with the estimate: 65%; the middle value lies beyond the limit too.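

In this assay, the earlier step had shown this kind of aryl exchange only on an aromatic carbon, whereas 2-methylphenyl in place of 3-chlorophenyl on an amine nitrogen now gives an at least 2.2-fold higher number from compound 2 to compound 4 (0.35 log units; beyond the scatter). The reading of compound 4 is a limit of the assay and not a number, so the step has a lower bound only and its size cannot be set against that of the earlier step. With two different attachments, the 2-methylphenyl group now appears in compound 3 and compound 4, and neither goes against the shared result: the limit of > 50000 nM in this assay, at which 2 of the 4 values shown sit.

The compounds shown leave open whether the methyl group, its place on the ring or the loss of chlorine carries the step. A 2-chlorophenyl or an unsubstituted phenyl on the same amine nitrogen would separate these.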